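The source may hold more compounds than are shown below. What is called first, only, known or untested is meant among the compounds shown, and "the series" means these compounds.

Measured in a functional assay on NCI-H460 cells (Homo sapiens) for cytotoxicity, read by MTT assay, with a stated time of 72 h; on this read-out lower numbers stand for stronger inhibition and higher numbers for weaker inhibition:
- compound 1 `CCCCCCCCNC1=CC(=O)C=C(C[C@]2(C)[C@@H](C)CC[C@]3(C)C(C)=CCC[C@@H]23)C1=O`: 38000 nM
- compound 2 `CCCCNC1=CC(=O)C(C[C@]2(C)[C@@H](C)CC[C@]3(C)C(C)=CCC[C@@H]23)=CC1=O`: > 100000 nM (a limit of the assay)
- compound 3 `CCCCCCCCNC1=CC(=O)C=C(C(C)(C)C)C1=O`: 20000 nM

Compound 3 and compound 1 lie within the scatter of each other, so their numbers do not separate them. For the measured compounds named here, they are the only two compounds here with a number rather than a limit.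

Compound 4 `CCNC1=CC(=O)C=C(C(C)(C)C)C1=O` differs from compound 3 in its amine chain: hydrogen in place of hexyl on a saturated chain carbon, two bonds along the chain from an amine nitrogen. Going by the values given here, no step between measured compounds that differ in one place is available, so the expectation rests on thin ground. Compound 2, which carries a butyl chain on its amine, reads > 100000 nM, and this too is only a limit. That value hints at weaker inhibition with a small amine chain, although compound 2 differs from compound 3 elsewhere as well. In this assay a moderate step towards a higher number is therefore expected. The estimated change is a 3.0-fold higher number from compound 3 to compound 4 (0.48 log units; beyond the scatter). For compound 4 the expected value is 60000 nM, with an estimated range from 20000 nM to 170000 nM.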

Compound 4, half-maximal inhibitory concentration: 13000 nM
For compound 4 the middle estimate is 4.6-fold (0.66 log units) above the measured one; measured number outside the range, below it.
By their numbers in this assay, from the lowest: compounds 4, 3 and 1 (each within the scatter of the next, the first and the last beyond it). At a limit, above all of these: compound 2.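

In this assay, hydrogen in place of hexyl on a saturated chain carbon, two bonds along the chain from an amine nitrogen, gives a 1.5-fold lower number from compound 3 to compound 4 (0.19 log units; within the scatter). For the compounds shown here, this is the first comparison here between compounds that differ in one place, and it shows that at this position the hexyl can go without a change that the assay can separate from scatter. Compound 2 gives only a limit and not a number, so it offers no measure of the effect of a small amine chain: the limit of > 100000 nM in this assay, at which 1 of the 4 values shown sits.

Going by these compounds, it remains open whether the same change would read alike on the core of compound 1. The compounds shown also leave open how an unsubstituted amine, a benzyl group or a chain ending in a carboxylic acid would read at this position.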